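Cyclohexyl urea analogue of compound 1 in the arrestin assay

This account rests on a few compounds, and the source may have more. Where it says the series, first, only, none or still open, it means among the compounds named here.

Three compounds of the series have been run in a functional assay on HEK293T cells for agonist activity at histamine H2 receptor (Homo sapiens), read by beta-arrestin recruitment; on this read-out lower numbers stand for smaller maximal responses and higher numbers for larger maximal responses. Compound 1 `CCCNC(=O)/N=C(\N)NCCCc1sc(N)nc1C` gives 0.32, compound 2 `N/C(=N\C(=O)NCc1ccccc1)NC1CCc2nc(N)sc2C1` gives 0.31, and compound 3 `Cc1nc(N)sc1CCCN/C(N)=N/C(=O)NCC(C)CCCc1ccccc1` gives 0.14. Compound 1 stands highest of the three, with compound 2 within the scatter of it and compound 3 beyond. For the measured compounds named here, the only single-place step measured is a number 0.18 lower from compound 1 to compound 3 (beyond the scatter), a drop on adding a large group to the chain. Compound 4 `Cc1nc(N)sc1CCCN/C(N)=N/C(=O)NC1CCCCC1` differs from compound 1 by cyclohexyl in place of propyl on an amide-type nitrogen. Going by the values given here, no measured step covers this change directly. Because a number 0.18 lower from compound 1 to compound 3 (beyond the scatter) came from adding a group larger than cyclohexyl, a smaller decrease is expected here. The expected step is a number 0.090 lower from compound 1 to compound 4 (within the scatter). Compound 4 is thus estimated at 0.23, in a range from 0.11 to 0.35.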

Compound 4, intrinsic activity: the largest response reached, as a fraction of the reference agonist's: 0.43
The estimate for compound 4 lay 0.20 below the measured number, outside the stated range (above it).
By their numbers in this assay, from the lowest: compound 3; then compounds 2 and 1 (each within the scatter of the next); then compound 4.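

In this assay, for the compounds shown here, the amide-type nitrogen carries cyclohexyl in place of propyl with a gain, a number 0.11 higher from compound 1 to compound 4 (beyond the scatter), the first upward step. The earlier step, a number 0.18 lower from compound 1 to compound 3 (beyond the scatter), went down on a larger group at a chain carbon, so among these compounds a larger group does not lower the response at every place. Nothing available accounts for the rise. Going by these compounds, whether it follows from the ring itself or from the larger carbon count stays open. A straight hexyl chain and a cyclopentyl ring on the same nitrogen would help separate the two.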